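The source may hold more compounds than are shown below. What is called first, only, known or untested is meant among the compounds shown, and "the series" means these compounds.

Of the compounds shown here, three that share one core have been tested in a functional assay on MCF7 cells (Homo sapiens) for antiproliferative activity; a higher number here means a weaker inhibitor, a lower number a stronger inhibitor. Compound 1 `COc1cc(Cc2nc3c(N)ncnc3n2CC2CCCCC2)cc(OC)c1OC` gives 39800 nM. Compound 2 `COc1cc(Cc2nc3c(N)nc(F)nc3n2CCOC(C)C)c(Cl)c(OC)c1OC` gives 5370 nM, and compound 3 `CCCCn1c(Cc2cc(OC)c(OC)c(OC)c2)nc2c(N)nc(F)nc21` gives 24000 nM. Compound 1 has the largest of these numbers, but its difference from compound 3 lies within the usual scatter, so those two cannot be separated; only compound 2 stands clearly beyond it. Compound 4 `COc1cc(Cc2nc3c(N)ncnc3n2CC2CCC2)cc(OC)c1OC` has not been measured. It differs from compound 1 in one place: cyclobutyl in place of cyclohexyl on a saturated chain carbon bound to an aromatic nitrogen. Going by the values given here, no measured pair shows this same change, so its effect is unknown. Only a small step is expected in this assay, perhaps slightly toward a weaker inhibitor, as a 1.3-fold higher number from compound 1 to compound 4 (0.10 log units; within the scatter), and it may not exceed the scatter. Compound 4 is therefore expected to give about 50000 nM, within 15000 nM to 150000 nM.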

Compound 4, half-maximal inhibitory concentration: 45700 nM
Estimate against measurement, compound 4: 1.1-fold (0.04 log units) above; measured number inside the range.
By their numbers in this assay, from the lowest: compound 2; then compounds 3, 1 and 4 (each within the scatter of the next).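

Replacing cyclohexyl with cyclobutyl on a saturated chain carbon bound to an aromatic nitrogen gives a 1.1-fold higher number from compound 1 to compound 4 (0.06 log units; within the scatter) in this assay. Going by these compounds alone, the earlier compounds differed from one another in several places, so this is the first reading of a single change at this position, and the two ring sizes cannot be told apart here. No measurement at hand offers an explanation for this result.

Going by these compounds, whether an amine or a carboxylic acid at this position would move the number beyond the scatter remains open. Also open, on these data alone, is whether the same ring change would read alike in compound 2 or compound 3.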